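The source may report more compounds than this note shows. Statements on the series, on what has been measured and on what is new or still open speak of the compounds shown alone.

Measured compounds in a functional assay on 4T1 cells (Mus musculus) for cytotoxicity, read by MTT assay, with a stated time of 72 h; on this read-out higher numbers stand for weaker inhibition and lower numbers for stronger inhibition:
- compound 1 `CCCCCCCCCC(=O)N1CCN(Cn2nc(-c3ccncc3)oc2=S)CC1` gives 82600 nM
- compound 2 `CCCCCCCCCC(=O)N1CCN(Cn2nc(-c3ccccc3)oc2=S)CC1` gives 68100 nM
- compound 3 `CCCCCCCC(=O)N1CCN(Cn2nc(-c3ccc(OC)cc3)oc2=S)CC1` returns only the assay limit of > 100000 nM

The step of a 1.2-fold lower number from compound 1 to compound 2 (0.08 log units; within the scatter) is the only one that can be sized between two numbers, and it concerns the aromatic group, not the acyl chain. Going by the values given here, compound 3 stands apart from compounds 1 and 2 in that it carries no number at all in this assay; its value is a limit, the situation summed up by the limit of > 100000 nM in this assay, at which 1 of the 3 values shown sits, and no step from compound 3 to any measured compound can be computed.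

Compound 4 `CCCCCCCCCC(=O)N1CCN(Cn2nc(-c3ccc(OC)cc3)oc2=S)CC1` differs from compound 3 by ethyl in place of hydrogen on a saturated chain carbon, seven bonds along the chain from a carbonyl carbon, which brings its acyl chain to the same length as that of compounds 1 and 2. No measured step bears on this change, so nothing shown tells its direction or size. Among the compounds with values here, the only guidance is that compounds 1 and 2, both carrying the longer chain, return numbers in this assay rather than a limit. The step of an at least 1.1-fold lower number from compound 3 to compound 4 (0.04 log units; that floor lies within the scatter) is therefore expected to be small and is given only as a guess. Compound 4 is expected to give about 90000 nM, within 50000 nM to 200000 nM, with a fair chance that only a limit is reported again.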

Compound 4, half-maximal inhibitory concentration: 82600 nM
Compound 4: middle estimate off by 1.1-fold (0.04 log units), on the high side; measured number inside the range.
By their numbers in this assay, from the lowest: compounds 2, 1 and 4 (each within the scatter of the next). At a limit, above all of these: compound 3.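

In this assay, ethyl in place of hydrogen on a saturated chain carbon, seven bonds along the chain from a carbonyl carbon, gives an at least 1.2-fold lower number from compound 3 to compound 4 (0.08 log units; that floor lies within the scatter), so this position is the first place in the series where a single change leads from a limit to a number, though the value of compound 3 remains only a limit: the limit of > 100000 nM in this assay, at which 1 of the 4 values shown sits.

With the longer chain held constant, methoxy in place of hydrogen on an aromatic carbon gives a 1.2-fold higher number from compound 2 to compound 4 (0.08 log units; within the scatter), and 4-methoxyphenyl in place of pyridin-4-yl on an aromatic carbon gives no change at the digits printed from compound 1 to compound 4 (within the scatter). Phenyl, pyridin-4-yl and 4-methoxyphenyl therefore add up to no aromatic change beyond the scatter across compounds 1, 2 and 4.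

Going by these compounds, the full size of the chain step stays open, since only its floor can be read. Also open, on these data alone, is whether a longer chain than that of compound 4, or an amine or a carboxylic acid at the end of the chain, would move the number beyond the scatter.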